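Lengthening the chain on a cyanoguanidine-bearing pyridazinone series

The compounds below may be only part of what the source reports. "The series", "measured", "known", "first", "only" and "open" are said of these compounds alone.

The measured compounds:
Compound 1, `C/N=C(\S)NCCCCCn1nc(-c2ccccc2)ccc1=O`, 35.3 mg/kg
Compound 2, `C/N=C(/NC#N)NCCCCCCn1nc(-c2ccccc2)ccc1=O`, > 100 mg/kg
Compound 3, `CC/N=C(/NC#N)NCCCCCn1nc(-c2ccccc2)ccc1=O`, 100 mg/kg

In a functional assay on the whole organism (stomach) with Rattus norvegicus as the target (on this read-out higher numbers stand for an effect only at larger amounts of compound and lower numbers for an effect already at smaller amounts), compound 1 gives 35.3 mg/kg. For compound 2 the result in this assay is a limit of the assay, > 100 mg/kg, not a number. Compound 3 gives 100 mg/kg in this assay, the highest of the two numbers recorded; its nearest neighbour is compound 1, with a 2.8-fold higher number from compound 1 to compound 3 (0.45 log units; beyond the scatter). The step of an at least 2.8-fold higher number from compound 1 to compound 2 (0.45 log units; beyond the scatter) also went upward, while a number no higher from compound 2 to compound 3 (the limit leaves the size open) cannot be sized, because one side of it is the limit described in the limit of > 100 mg/kg in this assay, at which 1 of the 3 values shown sits.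

Compound 4, `CN(C)/C(=N/CCCCCCn1nc(-c2ccccc2)ccc1=O)NC#N`, has not been measured in this assay. It differs from compound 3 by a group of 9 heavy atoms (5 carbon, 4 nitrogen; no ring) in place of a group of 8 heavy atoms (4 carbon, 4 nitrogen; no ring), on a saturated chain carbon, five bonds along the chain from an aromatic nitrogen. Going by the values given here, the steps at the same position, from compound 1 to compound 2 and from compound 2 to compound 3, both point to numbers at or around the top of the range recorded, and the one readable step there was upward. Compound 4 is therefore expected to sit near compound 3 or somewhat higher, that is a 1.3-fold higher number from compound 3 to compound 4 (0.11 log units; within the scatter), with a real chance that only a limit is returned. The estimate for compound 4 in this assay is 130 mg/kg, within a range from 50 mg/kg to 350 mg/kg.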

Compound 4, dose for half-maximal effect: 93.1 mg/kg
Estimate against measurement, compound 4: 1.4-fold (0.14 log units) above; the measured number falls inside the stated range.
By their numbers in this assay, from the lowest: compound 1; then compounds 4 and 3 (each within the scatter of the next).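

In this assay the group of 9 heavy atoms with 1 hydrogen-bond donor takes the place of the group of 8 heavy atoms with 2 hydrogen-bond donors, on a saturated chain carbon, five bonds along the chain from an aromatic nitrogen, and the result is a 1.1-fold lower number from compound 3 to compound 4 (0.03 log units; within the scatter). This gives a second cyanoguanidine-bearing compound with a readable number, and compound 1 remains apart from it, with a 2.6-fold higher number from compound 1 to compound 4 (0.42 log units; beyond the scatter). Compound 2 carries a limit and not a number, so the step of an at least 1.0-fold lower number from compound 2 to compound 4 (0.03 log units; that floor lies within the scatter) has an open size at one end: the limit of > 100 mg/kg in this assay, at which 1 of the 4 values shown sits.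

The compounds shown leave open how a carboxylic acid, a primary amine or a longer chain at this place would read in this assay. They also leave open whether the sulfur-bearing group of compound 1 would keep its lower number on the chain of compound 4, and which part of the exchanged group, if any, matters to the read-out.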